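Dichlorophenyl for nitrophenyl on the shared pyrazoline core

A few compounds are considered here, and "the series" means these few. Any claim that something is new, unique, unknown or untested is made for them only; others in the source may bear on it.

Measured so far, all in a functional assay on PC-3 cells (Homo sapiens) for cytotoxicity, read by sulforhodamine B assay, with a stated time of 48 h; a higher number here means a weaker inhibitor, a lower number a stronger inhibitor:
- Compound 1, `COc1cc(C2CC(c3ccco3)=NN2C(C)=O)cc(OC)c1OC`, gives 9650 nM.
- Compound 2, `CC(=O)N1N=C(c2cccc3ccccc23)CC1c1ccccc1`, gives 8460 nM.
- Compound 3, `CC(=O)N1N=C(c2cccc3ccccc23)CC1c1ccccc1[N+](=O)[O-]`, gives 3540 nM.

Compound 3 sits lowest of the three numbers in this assay; the nearest is compound 2 and the furthest compound 1, both beyond the scatter. Going by the values given here, the only single-point step so far is a 2.4-fold lower number from compound 2 to compound 3 (0.38 log units; beyond the scatter), a modest move from a hydrogen to a nitro group on the aromatic ring.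

Compound 4, `CC(=O)N1N=C(c2cccc3ccccc23)CC1c1cccc(Cl)c1Cl`, is the next member. It differs from compound 3 by 2,3-dichlorophenyl in place of 2-nitrophenyl on a saturated ring carbon. Among the compounds with values here, no measured pair exchanges a nitro group for chlorine, so the one step in hand, a 2.4-fold lower number from compound 2 to compound 3 (0.38 log units; beyond the scatter), bears on it only indirectly: it shows that a substituent on this ring can shift the number, but says nothing about which substituent. With compound 2 and compound 3 bracketing a narrow span, the change to compound 4 is expected to land within or just beyond the scatter, with no clear direction.

Compound 4 is therefore estimated at 4500 nM in this assay, between 1500 nM and 13000 nM, corresponding to an expected step of a 1.3-fold higher number from compound 3 to compound 4 (0.10 log units; within the scatter).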

Compound 4, half-maximal inhibitory concentration: 20100 nM
Estimate against measurement, compound 4: 4.5-fold (0.65 log units) below; the whole stated range lies below it.
By their numbers in this assay, from the lowest: compound 3; then compounds 2 and 1 (each within the scatter of the next); then compound 4.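

In this assay, the substituent pattern on the aryl group at this saturated ring carbon sets the direction of the step, not only its size: 2,3-dichlorophenyl in place of 2-nitrophenyl gives a 5.7-fold higher number from compound 3 to compound 4 (0.75 log units; beyond the scatter), and 2,3-dichlorophenyl in place of phenyl gives a 2.4-fold higher number from compound 2 to compound 4 (0.38 log units; beyond the scatter). Set against a 2.4-fold lower number from compound 2 to compound 3 (0.38 log units; beyond the scatter), this places the unsubstituted compound 2 between its two substituted partners, with the nitro group lowering the number and the dichloro pattern raising it, both beyond the scatter. No accompanying measurement bears on why the two substituents part in this way.

Going by these compounds, whether an amine or a carboxylic acid on this phenyl ring would follow the 2-nitrophenyl or the 2,3-dichlorophenyl direction remains open, as does whether a phenyl ring carrying one chlorine would match compound 4 or stay closer to compound 2. Compound 1 differs from the others in more than one place, so the shift seen here cannot be carried over to its furan-bearing scaffold.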